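A Second Hydroxy Group on the Shared Core

The compounds below may be only part of what the source reports. "The series", "measured", "known", "first", "only" and "open" are said of these compounds alone.

Compound 1 `O=c1oc2c(O)c(O)ccc2cc1-c1cccs1` gives > 30000 nM in a functional assay on isolated protein for antagonist activity at adenosine receptor A2b (Homo sapiens) (a higher number here means a weaker inhibitor, a lower number a stronger inhibitor), which is a limit of the assay rather than a number.
Compound 2 `O=c1oc2c(O)cccc2cc1-c1ccsc1` gives > 30000 nM in this assay, again a limit rather than a number.

Compound 2 therefore stands at the edge of what this assay can report, as does every value shown so far (the limit of > 30000 nM in this assay, at which 2 of the 2 values shown sit). Compound 3 `O=c1oc2c(O)c(O)ccc2cc1-c1ccsc1` differs from compound 2 by hydroxy in place of hydrogen on an aromatic carbon. Within the data shown here, no measured step covers this change. Since both measured compounds sit at the limit, no step beyond the usual scatter is expected, and a limit is the likely outcome again. Compound 3 is expected to give 50000 nM, within 20000 nM to 150000 nM. The expected step is a step that the limit leaves unreadable from compound 2 to compound 3.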

Compound 3, inhibition constant: > 30000 nM
Compound 3: a limit, no number (the forecaster's own chance of this, stated with the estimate: 85%); the middle value does not contradict the limit.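

Compound 3 gives no readable step from compound 1 or compound 2, because all three compounds stop at the same limit: the limit of > 30000 nM in this assay, at which 3 of the 3 values shown sit.

On these data alone, whether hydroxy in place of hydrogen, or thiophen-3-yl in place of thiophen-2-yl, changes the true strength in this assay stays open.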